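Pyridinyl Triazole Replaces Fluorophenyl in a Cytotoxic Series

This account rests on a few compounds, and the source may have more. Where it says the series, first, only, none or still open, it means among the compounds named here.

Compound 1 `C=C1C[C@]23C[C@@]1(O)CC[C@H]2c1ccc(O)c(C)c1[C@@H]3Cn1cc(-c2ccccc2)nn1` was tested in a functional assay on A549 cells (Homo sapiens) for cytotoxicity, read by MTT assay, with a stated time of 4 days (on this read-out higher numbers stand for weaker inhibition and lower numbers for stronger inhibition), and its result of > 20000 nM is a limit of the assay rather than a number. Within the data shown here, compound 2 `C=C1C(=O)[C@]23C[C@@]1(O)CC[C@H]2c1ccc(OS(=O)(=O)c2ccc(C)cc2)c(C)c1[C@@H]3Cn1cc(-c2ccc(F)cc2)nn1` gives 1950 nM in this assay, the only number among the two values shown. Compound 3 `C=C1C(=O)[C@]23C[C@@]1(O)CC[C@H]2c1ccc(OS(=O)(=O)c2ccc(C)cc2)c(C)c1[C@@H]3Cn1cc(-c2ccccn2)nn1` differs from compound 2 by pyridin-2-yl in place of 4-fluorophenyl on an aromatic carbon. No measured step of this kind exists among the compounds shown, so the step of a 1.3-fold higher number from compound 2 to compound 3 (0.11 log units; within the scatter) is expected to stay within the usual scatter, with no clear direction. Compound 3 is therefore estimated at 2500 nM, within 1000 nM to 8000 nM.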

Compound 3, half-maximal inhibitory concentration: 2310 nM
Compound 3: middle estimate off by 1.1-fold (0.03 log units), on the high side, within the range that was stated.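

In this assay, pyridin-2-yl in place of 4-fluorophenyl on this aromatic carbon gives a 1.2-fold higher number from compound 2 to compound 3 (0.07 log units; within the scatter). The position therefore accepts a six-membered aromatic ring with one hetero atom and one hydrogen-bond acceptor, with no clear difference from the 4-fluorophenyl ring. Nothing shown gives a cause for this outcome. What the compounds shown leave open is how this position reads with a group other than a six-membered aromatic ring, such as an amine, a carboxylic acid or a longer alkyl chain.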